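Neopentyl gives way to cyclohexyl: a clearance estimate

This account rests on a few compounds, and the source may have more. Where it says the series, first, only, none or still open, it means among the compounds named here.

Within the data shown here, in an ADME assay on liver for metabolic stability, with Liver microsome (Homo sapiens) as the target, read by LC-MS, using microsomes (on this read-out lower numbers stand for slow clearance and higher numbers for fast clearance), compound 1 (`CC(C)(C)C[C@@H](O)C(=O)N1N=CC[C@H]1C(=O)NCc1cc(Cl)ccc1-n1cnnn1`) gives 22 mL.min-1.g-1 as the only exact number so far. Compound 2 (`CC(C)(C)[C@@H](O)C(=O)N1C[S+]([O-])C[C@H]1C(=O)NCc1cc(Cl)ccc1-n1cnnn1`) returns < 12 mL.min-1.g-1 in this assay and that entry is a limit of the assay, not a number. Compound 3 (`O=C(NCc1cc(Cl)ccc1-n1cnnn1)[C@@H]1CC=NN1C(=O)[C@H](O)C1CCCCC1`) has not yet been measured. It keeps the core of compound 1 and changes one group, as counted here: cyclohexyl in place of neopentyl on a saturated chain carbon bound to a carbonyl carbon and an oxygen on a saturated carbon. Among the measured compounds shown here, no measured pair of compounds shows this swap, so the expectation rests on compound 1 alone and on how modest the change looks on paper. Little movement is expected in this assay beyond the usual scatter, with only a slight lean toward faster clearance. The estimated step runs a 1.1-fold higher number from compound 1 to compound 3 (0.06 log units; within the scatter) and stays inside that scatter. For compound 3 the expected value is 25 mL.min-1.g-1 with an estimated range from 12 mL.min-1.g-1 to 50 mL.min-1.g-1 as the likely span.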

Compound 3, intrinsic clearance in microsomes: 63 mL.min-1.g-1
Estimate against measurement, compound 3: 2.5-fold (0.40 log units) below; the measured number lies above the stated range.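

Among these compounds, until this result, no change at this position could be read, and compound 1 was the only exact number in this assay. Cyclohexyl in place of neopentyl on a saturated chain carbon bound to a carbonyl carbon and an oxygen on a saturated carbon gives a 2.9-fold higher number from compound 1 to compound 3 (0.46 log units; beyond the scatter), so this position is sensitive to the swap, and a change that looks small on paper can carry clearance past the usual scatter. No measurement shown here bears on what lies behind this step.

As far as these compounds go, with a single swap to read, it remains open whether the ring itself or simply the larger group goes with the faster clearance. From the compounds shown here alone, how a phenyl ring, an amine or a longer chain at the same place would read in this assay also remains open.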